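Trifluoromethyl Placement and a Further Trifluoromethyl Group

This account rests on a few compounds, and the source may have more. Where it says the series, first, only, none or still open, it means among the compounds named here.

Compound 1 `COc1cc(NC(C)CCCNC(=O)NNC(=O)Nc2ccc(C(F)(F)F)cc2)c2ncccc2c1`: 18000 nM
Compound 2 `COc1cc(NC(C)CCCNC(=O)NNC(=O)Nc2cccc(C(F)(F)F)c2)c2ncccc2c1`: 6900 nM

Both values come from a functional assay on CCRF-CEM cells (Homo sapiens) for inhibition, read by MTT assay, with a stated time of 72 h; a lower number here means a stronger inhibitor, a higher number a weaker inhibitor. Compound 2 has the lower number of the pair. The measured step is a 2.6-fold lower number from compound 1 to compound 2 (0.42 log units; beyond the scatter), a modest move beyond the scatter that came with 3-(trifluoromethyl)phenyl in place of 4-(trifluoromethyl)phenyl.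

Compound 3 `COc1cc(NC(C)CCCNC(=O)NNC(=O)Nc2cc(C(F)(F)F)cc(C(F)(F)F)c2)c2ncccc2c1` is the next structure to consider. The change is trifluoromethyl in place of hydrogen on an aromatic carbon, meta to a trifluoromethyl group.

Going by the values given here, only one measured step bears on this change, and it is indirect, since it relocates a trifluoromethyl group rather than adding one. Among the compounds with values here, no measured pair shows such an addition. Within the data shown here, compound 3 retains the trifluoromethyl group of compound 2 at 6900 nM, so a modest step to a lower number is expected in this assay, of about the size of the one measured step. The expected step is a 2.3-fold lower number from compound 2 to compound 3 (0.36 log units; beyond the scatter). For compound 3 the estimated value is 3000 nM, with an expected range of 1000 nM to 9000 nM.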

Compound 3, half-maximal inhibitory concentration: 13000 nM
For compound 3 the middle estimate is 4.3-fold (0.64 log units) below the measured one; the measured number lies above the stated range.
By their numbers in this assay, from the lowest: compounds 2, 3 and 1 (each within the scatter of the next, the first and the last beyond it).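

In this assay, trifluoromethyl in place of hydrogen on an aromatic carbon, meta to a trifluoromethyl group, gives a 1.9-fold higher number from compound 2 to compound 3 (0.28 log units; within the scatter), so compound 2 and compound 3 cannot be separated on this read-out. Going by these compounds alone, this is the first look at adding a trifluoromethyl group to this ring rather than relocating one: the relocation gave a 2.6-fold lower number from compound 1 to compound 2 (0.42 log units; beyond the scatter), a step beyond the scatter, whereas the addition leaves no step that can be read as a gain or a loss, and the series shows no benefit from the extra group at this carbon. Nothing on hand accounts for this outcome.

The compounds shown carry only trifluoromethyl on this ring, so it remains open whether a different group at the same aromatic carbon, such as a chlorine atom, a nitrile, an amine or a carboxylic acid, would give a number distinct from that of compound 2. Also open, going by these compounds, is whether the flat result holds when the chain linking the shared core to the urea-type portion is changed, for example to a shorter or longer chain.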